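Trimming the hydroxyethyl tail from the dinonyl aminoglycoside

A few compounds are considered here, and "the series" means these few. Any claim that something is new, unique, unknown or untested is made for them only; others in the source may bear on it.

Within the data shown here, compound 2 `CCCCCCCCCO[C@@H]1[C@@H](N)[C@@H](OCC(O)CNCCO)O[C@H](CN)[C@H]1OCCCCCCCCC` gives 99.1% in a toxicity assay on the whole organism (J774 cells) for cytotoxicity, with Mus musculus as the target, read by MTT assay, with a stated time of 24 h, tested at 10 uM (a higher number here means a weaker effect of the compound at the concentration tested, a lower number a stronger effect), the higher of the two numbers known, with compound 1 `CCCCCCCCCO[C@@H]1[C@@H](N)[C@@H](OCC(O)CNCCCO)O[C@H](CN)[C@H]1OCCCCCCCCC` nearest at 89.9%. Compound 3 `CCCCCCCCCO[C@@H]1[C@@H](N)[C@@H](OC[C@@H](O)CN)O[C@H](CN)[C@H]1OCCCCCCCCC` carries 2-amino-1-hydroxyethyl in place of 1-hydroxy-2-((2-hydroxyethyl)amino)ethyl on a saturated chain carbon bound to an oxygen on a saturated carbon. Among the measured compounds shown here, the only measured step, a number 9.2 percentage points higher from compound 1 to compound 2 (within the scatter), altered the same side chain by a single carbon and stayed within the scatter, which gives little reason to expect movement. Compound 3 is therefore expected to show a number 6.1 percentage points lower from compound 2 to compound 3 (within the scatter), a step of no consequence. The estimated value of compound 3 is 93%, between 80% and 102%.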

Compound 3, a percentage reported as activity, at one concentration (the size of the read-out at that concentration, not a potency): 85.1%
Compound 3: the middle estimate sits 7.9 percentage points above what was measured; the measured number falls inside the stated range.
By their numbers in this assay, from the lowest: compounds 3, 1 and 2 (each within the scatter of the next, the first and the last beyond it).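

In this assay, among these compounds, cutting 1-hydroxy-2-((2-hydroxyethyl)amino)ethyl back to 2-amino-1-hydroxyethyl gives a number 14 percentage points lower from compound 2 to compound 3 (beyond the scatter) and is the first change on this side chain to pass the scatter, though only modestly. Set against the 3-hydroxypropyl tail, the same cut gives a number 4.8 percentage points lower from compound 1 to compound 3 (within the scatter) and so cannot be told apart from no change. Nothing available accounts for this difference between the two steps.

As far as these compounds go, whether a carboxylic acid in place of the amine of 2-amino-1-hydroxyethyl, or a longer chain on that amine, would move the number remains open.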